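The source may hold more compounds than are shown below. What is called first, only, known or untested is meant among the compounds shown, and "the series" means these compounds.

Working notes on the series. In a functional assay on MOLT-4 cells (Homo sapiens) for inhibition, read by MTT assay, with a stated time of 72 h (a lower number here means a stronger inhibitor, a higher number a weaker inhibitor), compound 1 `COc1cc(NC(C)CCCNC(=O)Nc2ccc(C(F)(F)F)cc2)c2ncccc2c1` gives 20000 nM, compound 2 `COc1cc(NC(C)CCCNC(=O)NNC(=O)Nc2ccc(O)cc2)c2ncccc2c1` gives 104000 nM, and compound 3 `COc1cc(NC(C)CCCNC(=O)Nc2cccc(O)c2)c2ncccc2c1` gives 24000 nM. Compound 3 stands second highest of the three numbers: it sits close to compound 1, with a 1.2-fold higher number from compound 1 to compound 3 (0.08 log units; within the scatter), and well apart from compound 2, with a 4.3-fold lower number from compound 2 to compound 3 (0.64 log units; beyond the scatter).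

Compound 4 `COc1cc(NC(C)CCCNC(=O)Nc2ccc(Br)cc2)c2ncccc2c1` has not yet been measured in this assay. It differs from compound 3 by 4-bromophenyl in place of 3-hydroxyphenyl on an amide-type nitrogen. The step that bears most on this is the one between the two aryl ureas, where a 1.2-fold higher number from compound 1 to compound 3 (0.08 log units; within the scatter): swapping the aryl group on the amide-type nitrogen from 4-(trifluoromethyl)phenyl to 3-hydroxyphenyl changed little. The larger step, a 5.2-fold higher number from compound 1 to compound 2 (0.72 log units; beyond the scatter), involves a different kind of replacement and is less informative here. For compound 4 the expected step is therefore a 1.3-fold lower number from compound 3 to compound 4 (0.12 log units; within the scatter), a small move toward a lower number at most and likely within the scatter. The estimate for compound 4 in this assay is 18000 nM, with a range from 7000 nM to 45000 nM.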

Compound 4, half-maximal inhibitory concentration: 25000 nM
Beside the measured number, compound 4's estimate is 1.4-fold (0.14 log units) below it, and the stated range covers the measured number.
By their numbers in this assay, from the lowest: compounds 1, 3 and 4 (each within the scatter of the next); then compound 2.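

In this assay the step of a 1.0-fold higher number from compound 3 to compound 4 (0.02 log units; within the scatter) shows that 4-bromophenyl, with 0 hydrogen-bond donors and 0 hydrogen-bond acceptors, cannot be told apart from 3-hydroxyphenyl, with 1 of each, on this amide-type nitrogen. With the ring position held, bromo in place of trifluoromethyl on the aromatic carbon also leaves no readable difference, at a 1.3-fold higher number from compound 1 to compound 4 (0.10 log units; within the scatter), so three aryl groups on this nitrogen now fall within the scatter, while the ((4-hydroxyphenyl)carbamoyl)amino group stays apart, with a 4.2-fold lower number from compound 2 to compound 4 (0.62 log units; beyond the scatter). No available evidence bears on why these aryl groups give matching numbers.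

From the compounds shown here alone, whether an amine or a carboxylic acid on the aryl ring would shift the number remains open. So does whether a cyclohexyl group or a longer chain in place of the aryl ring would give a number outside this narrow band.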